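This account rests on a few compounds, and the source may have more. Where it says the series, first, only, none or still open, it means among the compounds named here.

Compound 1 (`Cc1cc(Cl)cc(-c2ccnc3cc(CN4C(=O)C5C(C4=O)C5(C)C)sc23)c1C[C@@H]1CNCCO1`): 450 nM
Compound 2 (`Cc1cc(Cl)cc(-c2ccnc3cc(CN4C(=O)CCC4=O)sc23)c1CN1CCNC[C@@H]1C`): "not determined" (no result reported)
Compound 3 (`Cc1cc(Cl)cc(-c2ccnc3cc(CN4C(=O)C5CC5C4=O)sc23)c1C[C@H]1OCCN[C@@H]1C`): "not determined" (no result reported)

Going by the values given here, in a functional assay on NCI-H526 cells (Homo sapiens) for cytotoxicity, read by CellTiter-Glo, with a stated time of 5 days (on this read-out lower numbers stand for higher toxicity in this test and higher numbers for lower toxicity in this test), compound 1 gives 450 nM as the only number in this set, so it cannot be ranked against any other compound. Compound 4 (`Cc1cc(Cl)cc(-c2ccnc3cc(CN4C(=O)C5CC5C4=O)sc23)c1C[C@@H]1CNCCO1`) has not yet been measured. It differs from compound 1 by a single change (a group of 8 heavy atoms (5 carbon, 1 nitrogen, 2 oxygen; one three-membered non-aromatic ring of carbon only, one five-membered non-aromatic ring with 1 hetero atom) in place of a group of 10 heavy atoms (7 carbon, 1 nitrogen, 2 oxygen; one three-membered non-aromatic ring of carbon only, one five-membered non-aromatic ring with 1 hetero atom), on a saturated chain carbon bound to an aromatic carbon) on a saturated chain carbon bound to an aromatic carbon. Among the compounds with values here, no measured pair shows the effect of such a change. Resting on compound 1 at 450 nM alone, no shift beyond the scatter is expected in this assay and neither direction is favoured. The estimated step of no change at the digits printed from compound 1 to compound 4 (within the scatter) is accordingly expected to be small. For compound 4 the estimate is 450 nM with an expected range from 130 nM to 1500 nM in this test.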

Compound 4, half-maximal cytotoxic concentration: 3600 nM
Compound 4: middle estimate off by 8.0-fold (0.90 log units), on the low side, and the stated range ends below it.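

In this assay, the place on a saturated chain carbon bound to an aromatic carbon proves sensitive: on the shared core, a group of 8 heavy atoms in place of a group of 10 heavy atoms gives an 8.0-fold higher number from compound 1 to compound 4 (0.90 log units; beyond the scatter), although both groups have the same ring types. Going by these compounds alone, this pair is the first reading of any single change in this set. No available evidence accounts for the step.

On these data alone, whether another group at this place, such as a longer chain or a carboxylic acid, would move the number in either direction stays open. So does whether the same change gives a similar step with a different amine-bearing ring elsewhere on the core.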